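From 3-methylphenyl to 2-methoxyphenyl on a shared core

The source may report more compounds than this note shows. Statements on the series, on what has been measured and on what is new or still open speak of the compounds shown alone.

Values measured in an ADME assay on NIH3T3 cells (Mus musculus) for cytotoxicity, with a stated time of 72 h (a higher number here means a weaker inhibitor, a lower number a stronger inhibitor), so far:
- compound 1 `OC[C@H]1O[C@@H](n2cnc3c(NCc4ccc(Cl)cc4)ncnc32)[C@H](O)[C@@H]1O` gives > 166000 nM (a limit)
- compound 2 `Cc1cccc(CNc2ncnc3c2ncn3[C@@H]2O[C@H](CO)[C@@H](O)[C@H]2O)c1` gives > 166000 nM (a limit)

For compound 2 the reading > 166000 nM is a limit and not a number. The next compound, compound 3 `COc1ccccc1CNc1ncnc2c1ncn2[C@@H]1O[C@H](CO)[C@@H](O)[C@H]1O`, carries 2-methoxyphenyl in place of 3-methylphenyl on a saturated chain carbon bound to a nitrogen on an aromatic ring. Within the data shown here, the only measured change at this place is a step that the two limits leave unreadable from compound 1 to compound 2, so there is no measured size to carry over. Compound 1 and compound 2 both rest at the limit of > 166000 nM in this assay, at which 2 of the 2 values shown sit, so no step beyond the scatter is expected in this assay for this change. The expected step is a number no higher from compound 2 to compound 3 (the limit leaves the size open) by this estimate. For compound 3 the estimated value is 166000 nM, with an expected range from 90000 nM to 300000 nM in this estimate.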

Compound 3, half-maximal inhibitory concentration: 140000 nM
Estimate against measurement, compound 3: 1.2-fold (0.07 log units) above; low and high end bracket the measured number.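

Among these compounds, compound 3 is the first compound here to give a measured number rather than a limit in this assay, so a change at this place can leave the reading within what the assay reports. The reading shows an at least 1.1-fold lower number from compound 2 to compound 3 (0.07 log units; that floor lies within the scatter), and it also shows an at least 1.1-fold lower number from compound 1 to compound 3 (0.07 log units; that floor lies within the scatter). Both steps are floors on the true size, so neither establishes a difference beyond the usual scatter, and the other two compounds remain a limit and not a number: the limit of > 166000 nM in this assay, at which 2 of the 3 values shown sit.

The compounds shown leave open whether the methoxy group itself or its place on the ring accounts for the measured reading, which 3-methoxyphenyl at the same place could help separate. They also leave open whether an amine, a carboxylic acid or a longer chain at this place would give a clearly lower number.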